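A few compounds are considered here, and "the series" means these few. Any claim that something is new, unique, unknown or untested is made for them only; others in the source may bear on it.

Measured so far in a functional assay on CHO-K1 cells for antagonist activity at Orexin/Hypocretin receptor type 1 (Homo sapiens), read by FLIPR and calcium flux; a higher number here means a weaker inhibitor, a lower number a stronger inhibitor:
compound 1 `CCc1ccnc(O[C@@H]2CC[C@@H](C)N(C(=O)c3ccccc3-n3nccn3)C2)c1` — 310 nM
compound 2 `COC(=O)c1ccnc(O[C@@H]2CC[C@@H](C)N(C(=O)c3ccccc3-n3nccn3)C2)c1` — 1800 nM
compound 3 `C[C@@H]1CC[C@@H](Oc2cc(Br)ccn2)CN1C(=O)c1ccccc1-n1nccn1` — 380 nM

Of the three numbers compound 3 holds the second highest. The two steps into compound 3 are a 1.2-fold higher number from compound 1 to compound 3 (0.09 log units; within the scatter) and a 4.7-fold lower number from compound 2 to compound 3 (0.68 log units; beyond the scatter), the first within the scatter, the second beyond it. Compound 4 `C[C@@H]1CC[C@@H](Oc2cc(-c3ccccc3)ccn2)CN1C(=O)c1ccccc1-n1nccn1` differs from compound 3 by phenyl in place of bromo on an aromatic carbon. Within the data shown here, no measured step introduces a phenyl at this carbon; the steps that touch the position, a 1.2-fold higher number from compound 1 to compound 3 (0.09 log units; within the scatter) and a 5.8-fold higher number from compound 1 to compound 2 (0.76 log units; beyond the scatter), show one small and one modest change, so the direction for a phenyl cannot be read from them. For compound 4 a step of a 1.3-fold lower number from compound 3 to compound 4 (0.10 log units; within the scatter) is expected, with wide uncertainty. Compound 4 is therefore estimated at 300 nM, ranging from 80 nM to 1200 nM.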

Compound 4, half-maximal inhibitory concentration: 2400 nM
The estimate for compound 4 lay 8.0-fold (0.90 log units) below the measured number, outside the stated range (above it).
By their numbers in this assay, from the lowest: compounds 1 and 3 (each within the scatter of the next); then compounds 2 and 4 (each within the scatter of the next).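

In this assay the phenyl opposite the ring nitrogen costs potency, with a 6.3-fold higher number from compound 3 to compound 4 (0.80 log units; beyond the scatter) and a 7.7-fold higher number from compound 1 to compound 4 (0.89 log units; beyond the scatter) both beyond the scatter, so this carbon does not accept every group alike. Against methoxycarbonyl, a 1.3-fold higher number from compound 2 to compound 4 (0.12 log units; within the scatter) lies within the scatter, which places these two groups together at the weak end of the series and ethyl and bromo at the strong end. Nothing measured here explains the loss.

As far as these compounds go, whether a methoxy or an amine at this carbon would read with ethyl and bromo or with phenyl and methoxycarbonyl stays open. So does whether a longer alkyl chain would match ethyl or phenyl.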